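A few compounds are considered here, and "the series" means these few. Any claim that something is new, unique, unknown or untested is made for them only; others in the source may bear on it.

Measured in an in vivo ADME assay on the whole organism (strain Sprague-Dawley) for pharmacokinetics, with Rattus norvegicus as the target; on this read-out higher numbers stand for higher oral bioavailability and lower numbers for lower oral bioavailability:
- compound 1 `COc1cc(C(=O)N2[C@@H](c3nccs3)[C@@H](C(N)=O)C[C@@]2(CC(C)C)C(=O)O)ccc1C(C)(C)C`: 0.6%
- compound 2 `COC[C@H]1C[C@@](CC(C)C)(C(=O)O)N(C(=O)c2ccc(C(C)(C)C)c(OC)c2)[C@H]1c1nccs1`: 59%
- compound 3 `COc1cc(C(=O)N2[C@@H](c3nccs3)[C@H](CO)C[C@@]2(CC(C)C)C(=O)O)ccc1C(C)(C)C`: 11%

Compound 3, at 11%, ranks second of the three, above compound 1 and below compound 2. Next is compound 4 `COc1cc(C(=O)N2[C@@H](c3nccs3)[C@@H](CO)C[C@@]2(CC(C)C)C(=O)O)ccc1C(C)(C)C`. The change from compound 3 is the two compounds have the same atoms and bonds and differ only in configuration as drawn: 1 of 3 stereo elements differ; a stereocentre at a saturated ring carbon is drawn R in compound 3 and S in compound 4.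

Within the data shown here, the only measured step, a number 58.4 percentage points higher from compound 1 to compound 2 (beyond the scatter), is large but exchanges carbamoyl for methoxymethyl on a saturated ring carbon. Among the measured compounds shown here, it bears only indirectly, since no measured step isolates configuration. Going by these compounds, the size of any configuration effect in this assay remains unknown, so only a modest rise is expected. The expected change is a number 9 percentage points higher from compound 3 to compound 4 (within the scatter). For compound 4, the estimated value is 20%, with an expected range of 5% to 45%.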

Compound 4, oral bioavailability: 12%
Compound 4: middle estimate off by 8 percentage points, on the high side; measured number inside the range.
By their numbers in this assay, from the lowest: compound 1; then compounds 3 and 4 (each within the scatter of the next); then compound 2.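

At this saturated ring carbon, configuration is now isolated: the fact that compounds 3 and 4 differ only in the configuration as drawn. With hydroxymethyl in place, going from R to S gives a number 1 percentage points higher from compound 3 to compound 4 (within the scatter), whereas hydrogen in place of methyl on the oxygen gives a number 47 percentage points lower from compound 2 to compound 4 (beyond the scatter), and hydroxymethyl in place of carbamoyl gives a number 11.4 percentage points higher from compound 1 to compound 4 (beyond the scatter). In this assay, the steps beyond the scatter among these compounds therefore come from the substituent, not from its drawn configuration in the one pair available.

Going by these compounds, the effect of configuration with methoxymethyl at this carbon remains open. So does the reading for a longer ether chain such as ethoxymethyl, or for an amine such as aminomethyl.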